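A few compounds are considered here, and "the series" means these few. Any claim that something is new, unique, unknown or untested is made for them only; others in the source may bear on it.

In an assay on CHO cells for displacement of a labelled ligand from adenosine receptor A1 (Homo sapiens), read by scintillation counting, with a stated time of 60 min, tested at 10 uM (on this read-out higher numbers stand for more inhibition at the one concentration tested (going by the name of the read-out) and lower numbers for less inhibition), compound 1 `O=C(NC1CCCC1)c1cc2ccccc2oc1=O` gives 16%. Compound 2 `O=C(NCCCO)c1cc2ccccc2oc1=O` carries one change on the same core: 3-hydroxypropyl in place of cyclopentyl on an amide-type nitrogen. In this assay compound 2 gives 24%, and the step is a number 8 percentage points higher from compound 1 to compound 2 (within the scatter), so the two numbers cannot be told apart with confidence.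

Compound 3 `N=c1oc2ccc(Br)cc2cc1C(=O)NC1CCCC1` is built on a different core; how its core differs from that of compound 1 is not broken down here. In this assay compound 3 gives 17%, a number close to that of compound 1 and within the scatter of compound 2 as well, so no ordering among the three compounds can be read from these values.

Compound 4 `N=c1oc2ccc(Br)cc2cc1C(=O)NCCCO` has not yet been measured. It stands to compound 3 exactly as compound 2 stands to compound 1: 3-hydroxypropyl in place of cyclopentyl on an amide-type nitrogen. The place of the change is the same on both cores, an amide-type nitrogen whose other neighbour is a carbonyl carbon, so this is the same change made once more.

Among the measured compounds shown here, the only guide is the measured pair. Because a number 8 percentage points higher from compound 1 to compound 2 (within the scatter) lay within the scatter, the same change on the core of compound 3 is expected to move the number only a little, and the step is estimated as a number 8 percentage points higher from compound 3 to compound 4 (within the scatter). Compound 4 is expected to give about 25% in this assay, with a plausible range from 8% to 42%. This expectation rests on a single measured pair and is therefore loose.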

Compound 4, a percentage reported as inhibition, at one concentration (the size of the read-out at that concentration, not a potency): 32%
Estimate against measurement, compound 4: 7 percentage points below; low and high end bracket the measured number.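

In this assay, placing 3-hydroxypropyl in place of cyclopentyl on the amide-type nitrogen of the core of compound 3 gives a number 15 percentage points higher from compound 3 to compound 4 (beyond the scatter). The same change on the core of compound 1 gave a step in the same direction, and the two steps cannot be told apart: the same change on two cores in this assay, a number 8 percentage points higher (within the scatter) from compound 1 to compound 2 and a number 15 percentage points higher (beyond the scatter) from compound 3 to compound 4, 7 percentage points apart, within the scatter of two such steps. Among the compounds shown here, this shows that, on these two cores, the change carries over without any sign that the core alters its effect, but it does not show that the step has one fixed size, that the core of compound 3 responds more strongly than the core of compound 1, or that the result would hold on a third core, and each core offers only a single pair read at one concentration.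

The compounds shown leave open whether the step belongs to the oxygen of the 3-hydroxypropyl group or to the swap of a ring for an open chain, a question that a plain propyl chain on the same nitrogen could help to separate. They also leave open how a longer hydroxyalkyl chain, an amine or a carboxylic acid at the end of the chain would read in this assay.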